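Swapping the Hydrazone Aryl Group on a Triazine Core

The compounds below may be only part of what the source reports. "The series", "measured", "known", "first", "only" and "open" are said of these compounds alone.

Measured so far:
Compound 1, `NS(=O)(=O)c1ccc(Nc2nc(N/N=C/c3ccc(C(F)(F)F)cc3)nc(Nc3ccccc3)n2)cc1`, gives 1880 nM in a functional assay on UO-31 cells (Homo sapiens) for inhibition, read by sulforhodamine B assay, with a stated time of 48 h; a higher number here means a weaker inhibitor of growth, a lower number a stronger inhibitor of growth.
Compound 2, `Cc1nn(-c2ccccc2)cc1/C=N/Nc1nc(Nc2ccccc2)nc(Nc2ccc(S(N)(=O)=O)cc2)n1`, gives 1720 nM in this assay.

Within the data shown here, compound 2 is one of only two compounds measured, and its value and that of compound 1 lie within the usual scatter of each other, so neither can be called the stronger. Among the measured compounds shown here, the one step known so far, a 1.1-fold lower number from compound 1 to compound 2 (0.04 log units; within the scatter), exchanged the aryl group on the hydrazone carbon and left the number essentially unchanged.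

Compound 3, `NS(=O)(=O)c1ccc(Nc2nc(N/N=C/c3ccccn3)nc(Nc3ccccc3)n2)cc1`, is the next change at the same place: pyridin-2-yl in place of 3-methyl-1-phenyl-1H-pyrazol-4-yl on a carbon with a double bond to nitrogen. For the measured compounds named here, the only step that bears on it is the one from compound 1 to compound 2, which shows that changing this aryl group, at least once, made no difference beyond the scatter. The step from compound 2 to compound 3 is therefore expected to be a 1.2-fold higher number from compound 2 to compound 3 (0.07 log units; within the scatter), with no clear direction. Compound 3 is estimated at 2000 nM in this assay, within a range from 900 nM to 4500 nM.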

Compound 3, concentration for 50% growth inhibition: 1500 nM
Beside the measured number, compound 3's estimate is 1.3-fold (0.12 log units) above it; the measured number falls inside the stated range.
By their numbers in this assay, from the lowest: compounds 3, 2 and 1 (each within the scatter of the next).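

Exchanging the group at this position has no clear effect: 3-methyl-1-phenyl-1H-pyrazol-4-yl, with 12 heavy atoms, gives way to pyridin-2-yl, with 6, and this assay shows a 1.1-fold lower number from compound 2 to compound 3 (0.06 log units; within the scatter). Replacing 4-(trifluoromethyl)phenyl with pyridin-2-yl, which brings a nitrogen into the six-membered aromatic ring, likewise gives a 1.3-fold lower number from compound 1 to compound 3 (0.10 log units; within the scatter). Among these three aromatic groups, therefore, the carbon with a double bond to nitrogen tolerates changes in ring type and size with no difference that can be read, and no separate measurement is available to explain this.

Going by these compounds, it remains open whether a group of a different kind here, such as a longer alkyl chain, a carboxylic acid or an amine, would move the number beyond the scatter. These three compounds also say nothing about changes elsewhere on the shared core.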